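Lengthening the Amine Chain on a Shared Core

The compounds below may be only part of what the source reports. "The series", "measured", "known", "first", "only" and "open" are said of these compounds alone.

Measured so far in an assay on isolated protein for inhibition of phosphodiesterase 1 (Bos taurus), read by cAMP accumulation; a higher number here means a weaker inhibitor, a lower number a stronger inhibitor:
Compound 1, `CNc1ccc(C2c3ccccc3N=C(NCCCCN)C2(C)C)cc1`: 373000 nM
Compound 2, `CNc1ccc(C2c3ccccc3N=C(NCCCNCCCCN)C2(C)C)cc1`: 64000 nM

Both compounds share the same core and differ only in the chain that hangs from the amidine-like nitrogen. For the measured compounds named here, compound 2 gives the lowest number of the two measured compounds, and the only neighbour on the scale is compound 1, which sits well above it: the change a 5.8-fold lower number from compound 1 to compound 2 (0.77 log units; beyond the scatter) lengthened the chain by inserting a further amine, and the number fell clearly beyond the scatter.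

Compound 3, `CNc1ccc(C2c3ccccc3N=C(NCCCNCCCCNCCCN)C2(C)C)cc1`, carries this idea one step further. The change from compound 2 is 3-aminopropyl in place of hydrogen on an amine nitrogen; once again the chain grows by a segment ending in an amine. Going by the values given here, the single measured step that bears on this, the one from compound 1 to compound 2, was a modest but clear gain. If chain extension keeps helping in the same way, a similar improvement is expected, and compound 3 is estimated to lie at 15000 nM, within a range from 5000 nM to 50000 nM, which corresponds to an expected step of a 4.3-fold lower number from compound 2 to compound 3 (0.63 log units; beyond the scatter).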

Compound 3, half-maximal inhibitory concentration: 23000 nM
The estimate for compound 3 lay 1.5-fold (0.19 log units) below the measured number; the measured number falls inside the stated range.
By their numbers in this assay, from the lowest: compound 3; then compound 2; then compound 1.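

In this assay, 3-aminopropyl in place of hydrogen on an amine nitrogen gives a 2.8-fold lower number from compound 2 to compound 3 (0.44 log units; beyond the scatter) and so counts as a modest gain, which shows that the lowering does not stop after the first added amine segment. Across the whole chain, the two extensions together give a 16-fold lower number from compound 1 to compound 3 (1.21 log units; beyond the scatter) and amount to a large step, so the three compounds now stand in one order, with the number falling as the chain grows and no compound going against it. No measurement here explains why the longer chains give lower numbers.

For the compounds shown here, two extensions cannot tell whether the gain is levelling off or whether a longer chain carrying a further aminopropyl segment would lower the number again, and even compound 3 remains at 23000 nM as the best number so far. From the compounds shown here alone, it also remains open whether the inner amine nitrogens themselves matter or length alone does, a question that a chain of the same length with an ether oxygen or a plain methylene in their place could settle.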